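Propoxymethyl in Place of Amino on the Shared Core

A few compounds are considered here, and "the series" means these few. Any claim that something is new, unique, unknown or untested is made for them only; others in the source may bear on it.

Compound 1 `CCCCc1c(F)c(N)c2c(=O)cc(-c3ccc(N)c(F)c3)oc2c1F` gives 8800 nM in a functional assay on MCF7 cells (Homo sapiens) for cytotoxicity, read by neutral red uptake, with a stated time of 3 days; a lower number here means a stronger inhibitor, a higher number a weaker inhibitor.
Compound 2 `[N-]=[N+]=Nc1c(F)c(N)c2c(=O)cc(-c3ccc(N)c(F)c3)oc2c1F` gives 460 nM in this assay.
Compound 3 `Nc1ccc(-c2cc(=O)c3c(N)c(F)c(N)c(F)c3o2)cc1F` gives 7.7 nM in this assay.

Compound 3 has the lowest number of the three, and both gaps lie beyond the scatter: the nearest is a 60-fold lower number from compound 2 to compound 3 (1.78 log units; beyond the scatter) and the furthest is a 1100-fold lower number from compound 1 to compound 3 (3.06 log units; beyond the scatter). Compound 4 `CCCOCc1c(F)c(N)c2c(=O)cc(-c3ccc(N)c(F)c3)oc2c1F` differs from compound 3 by propoxymethyl in place of amino on an aromatic carbon. The step that bears most on this change is the one in which butyl was replaced by amino, a 1100-fold lower number from compound 1 to compound 3 (3.06 log units; beyond the scatter), a large drop; its reverse is what the new chain resembles. The step of a 19-fold lower number from compound 1 to compound 2 (1.28 log units; beyond the scatter) shows that even azido sits far below butyl. A large rise is therefore expected, a 650-fold higher number from compound 3 to compound 4 (2.81 log units; beyond the scatter), for compound 4. Compound 4 is estimated at 5000 nM, within a range from 1000 nM to 20000 nM.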

Compound 4, half-maximal inhibitory concentration: 1200 nM
For compound 4 the middle estimate is 4.2-fold (0.62 log units) above the measured one; the measured number falls inside the stated range.
By their numbers in this assay, from the lowest: compound 3; then compound 2; then compound 4; then compound 1.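

In this assay, the atoms of the chain matter at this position, and not only its length: propoxy in place of propyl on the chain brings a clear drop (a 7.3-fold lower number from compound 1 to compound 4 (0.87 log units; beyond the scatter)). Even so, this chain comes nowhere near amino (a 160-fold higher number from compound 3 to compound 4 (2.19 log units; beyond the scatter)) and stays modestly behind azido (a 2.6-fold higher number from compound 2 to compound 4 (0.42 log units; beyond the scatter)).

No measured evidence here accounts for these gaps. As far as these compounds go, whether a shorter chain such as methoxymethyl, or a chain ending in an amine such as aminomethyl, would come closer to amino stays open.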